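The source may report more compounds than this note shows. Statements on the series, on what has been measured and on what is new or still open speak of the compounds shown alone.

Measured so far:
compound 1 `CNC(=O)/C=C/c1ccncc1-c1ccc2ccccc2c1` — 8680 nM
compound 2 `Cn1ncc2cc(-c3cnccc3/C=C/C(=O)O)ccc21` — > 10000 nM

In a functional assay on MDA-MB-231 cells (Homo sapiens) for inhibition, read by sulforhodamine B assay, with a stated time of 72 h (on this read-out lower numbers stand for stronger inhibition of growth and higher numbers for weaker inhibition of growth), compound 1 gives 8680 nM, the only plain number shown. The value of compound 2 is the limit of > 10000 nM in this assay, at which 1 of the 2 values shown sits, a limit of the assay and not a number. No step between measured compounds is shown. Compound 3 `O=C(O)CCc1ccncc1-c1ccc2ccccc2c1` differs from compound 1 by 2-carboxyethyl in place of 2-(methylcarbamoyl)ethenyl on an aromatic carbon. In this assay a weakening somewhat beyond the scatter is expected, a 1.7-fold higher number from compound 1 to compound 3 (0.24 log units; within the scatter). Compound 3 is estimated at 15000 nM, with a range from 5000 nM to 50000 nM, and a fair chance that only a limit is reported.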

Compound 3, concentration for 50% growth inhibition: > 10000 nM
Compound 3: a limit, no number (the forecaster's own chance of this, stated with the estimate: 55%); the middle value is on the limit's open side.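

Replacing 2-(methylcarbamoyl)ethenyl with 2-carboxyethyl on this aromatic carbon, opposite the ring nitrogen, gives an at least 1.1-fold higher number from compound 1 to compound 3 (0.06 log units; that floor lies within the scatter) in this assay. The result for compound 3 is a limit, not a number, and the true size of the step cannot be read. Limits now make up most of the set: the limit of > 10000 nM in this assay, at which 2 of the 3 values shown sit.

The change to compound 3 alters the chain's end group and its double bonds together, and the compounds shown do not separate the two. From the compounds shown here alone, how an amine or a longer chain would read at this position also remains open.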